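This account rests on a few compounds, and the source may have more. Where it says the series, first, only, none or still open, it means among the compounds named here.

Measured so far in an ADME assay on microsomes from liver (Mus musculus, strain CD1) for metabolic stability, read by HPLC, with a stated time of 30 min, tested at 1 uM; on this read-out lower numbers stand for slow clearance and higher numbers for fast clearance:
Compound 1 `O=S(=O)(Nc1c(N2CCCC2)ccc2ncccc12)c1ccc(Br)cc1`: 27 mL.min-1.g-1
Compound 2 `Cc1ccc2ncccc2c1NS(=O)(=O)c1ccc(Br)cc1`: 3.6 mL.min-1.g-1
Compound 3 `O=S(=O)(Nc1c(CC2CCCCC2)ccc2ncccc12)c1ccc(Br)cc1`: 33 mL.min-1.g-1

In this assay compound 3 sits at the upper end of these numbers together with compound 1, the two lying within the scatter of each other in a 1.2-fold higher number from compound 1 to compound 3 (0.09 log units; within the scatter). Compound 2 stands well apart from both, as a 7.5-fold lower number from compound 1 to compound 2 (0.88 log units; beyond the scatter) and a 9.2-fold higher number from compound 2 to compound 3 (0.96 log units; beyond the scatter) show.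

Compound 4 `O=S(=O)(Nc1c(Cc2ccccc2)ccc2ncccc12)c1ccc(Br)cc1` carries a single change from compound 3: phenyl in place of cyclohexyl on a saturated chain carbon bound to an aromatic carbon. For the measured compounds named here, no measured step exchanges these two rings, so the evidence is indirect. The nearest guide is a 9.2-fold higher number from compound 2 to compound 3 (0.96 log units; beyond the scatter), in which cyclohexyl replaced hydrogen at that same place. Compound 4 keeps a ring there, so most of that rise is expected to remain, leaving a step within the scatter that leans towards a lower number.

The expected step is a 1.5-fold lower number from compound 3 to compound 4 (0.18 log units; within the scatter). For compound 4 the estimated value is 22 mL.min-1.g-1, with an expected range of 10 mL.min-1.g-1 to 42 mL.min-1.g-1.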

Compound 4, intrinsic clearance in microsomes: 23 mL.min-1.g-1
Beside the measured number, compound 4's estimate is 1.0-fold (0.02 log units) below it; the range from low to high includes it.
By their numbers in this assay, from the lowest: compound 2; then compounds 4, 1 and 3 (each within the scatter of the next).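

In this assay, the step from a saturated to an aromatic ring on a saturated chain carbon bound to an aromatic carbon stays within the scatter (a 1.4-fold lower number from compound 3 to compound 4 (0.16 log units; within the scatter)), so this position tolerates either ring without a readable change. Phenyl, like cyclohexyl, stands well apart from the hydrogen of compound 2 (a 6.4-fold higher number from compound 2 to compound 4 (0.81 log units; beyond the scatter)), and benzyl cannot be told from pyrrolidin-1-yl on the aromatic carbon (a 1.2-fold lower number from compound 1 to compound 4 (0.07 log units; within the scatter)), so all three larger groups now read alike, against compound 2 alone. Nothing measured here explains why these groups read alike or differ from compound 2.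

The compounds shown leave open whether a fluorine or a nitrile on the phenyl would move the number. They also leave open whether a longer open chain without any ring would read like these groups or like compound 2.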